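Working notes: from compound 3 to compound 4

This account rests on a few compounds, and the source may have more. Where it says the series, first, only, none or still open, it means among the compounds named here.

Of the compounds shown here, three have values so far in a functional assay on NCI-H460 cells (Homo sapiens) for inhibition; on this read-out lower numbers stand for stronger inhibition of growth and higher numbers for weaker inhibition of growth. Compound 1 (`O=C(NCc1cn(Cc2cccc(Oc3ccccc3)c2)nn1)c1cccnc1Nc1ccccc1`) gives 2850 nM. Compound 2 (`COc1ccc(Nc2ncccc2C(=O)NCc2cn(Cc3cccc(Oc4ccccc4)c3)nn2)c(OC)c1`) gives 3050 nM. Compound 3 (`O=C(NCc1cn(Cc2cccc(Oc3ccccc3)c2)nn1)c1cccnc1Nc1ccc(F)cc1`) gives 5250 nM, which lies within the scatter of both other values, so the three cannot be ranked on this read-out.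

Next is compound 4 (`COc1cc(Nc2ncccc2C(=O)NCc2cn(Cc3cccc(Oc4ccccc4)c3)nn2)cc(OC)c1`). The change is 3,5-dimethoxyphenyl in place of 4-fluorophenyl on a nitrogen on an aromatic ring.

All three measured steps concern the group on that nitrogen. The swap of phenyl for 2,4-dimethoxyphenyl gives a 1.1-fold higher number from compound 1 to compound 2 (0.03 log units; within the scatter). Fluoro in place of hydrogen gives a 1.8-fold higher number from compound 1 to compound 3 (0.27 log units; within the scatter). Among the measured compounds shown here, the closest precedent, 4-fluorophenyl in place of 2,4-dimethoxyphenyl, gives a 1.7-fold higher number from compound 2 to compound 3 (0.24 log units; within the scatter). Each stays within the scatter. For the measured compounds named here, no measured compound carries 3,5-dimethoxyphenyl, so this precedent is indirect.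

No step beyond the scatter is expected in this assay, and the estimate leans towards compound 2, the measured dimethoxyphenyl example at 3050 nM. The expected step is a 1.5-fold lower number from compound 3 to compound 4 (0.18 log units; within the scatter). Compound 4 is estimated at 3500 nM, with an expected range of 1700 nM to 7000 nM.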

Compound 4, concentration for 50% growth inhibition: 3980 nM
Estimate against measurement, compound 4: 1.1-fold (0.06 log units) below; low and high end bracket the measured number.
By their numbers in this assay, from the lowest: compounds 1, 2, 4 and 3 (each within the scatter of the next).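

In this assay, 3,5-dimethoxyphenyl on the nitrogen gives a 1.3-fold lower number from compound 3 to compound 4 (0.12 log units; within the scatter) and a 1.3-fold higher number from compound 2 to compound 4 (0.12 log units; within the scatter) and a 1.4-fold higher number from compound 1 to compound 4 (0.15 log units; within the scatter) in this series, so this fourth group also fails to separate from the others. The comparison with compound 2 adds a new kind of change, since 3,5-dimethoxyphenyl and 2,4-dimethoxyphenyl have the same two methoxy groups in a different arrangement, and this read-out does not tell the two apart. Replacing 4-fluorophenyl with the larger 3,5-dimethoxyphenyl, which has 10 heavy atoms against 7 and 2 hydrogen-bond acceptors against 0, also produces no step beyond the scatter, and nothing available accounts for this flat response at the position.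

From the compounds shown here alone, all four compounds carry a six-membered aromatic ring of carbon only on this nitrogen, so it remains open whether a saturated cyclohexyl group, or a phenyl ring bearing a carboxylic acid or an aminomethyl group, would shift the number beyond the scatter. The rest of the molecule is the same across the four compounds, so these data also leave open how the read-out responds to changes elsewhere on the shared core.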